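From 3-Methylphenyl to 5-Fluoropyridin-2-yl on a Shared Core

A few compounds are considered here, and "the series" means these few. Any claim that something is new, unique, unknown or untested is made for them only; others in the source may bear on it.

Of the compounds shown here, three sharing one core have been tested so far in an ADME assay on CHO cells (Cricetulus griseus) for cytotoxicity, read by LDH release (on this read-out lower numbers stand for stronger inhibition and higher numbers for weaker inhibition), with closely matching results. Compound 1 `CC(Oc1ccc(Cl)cc1Cl)C(=O)NCc1ccccc1F` gives 47000 nM there, compound 2 `CC(Oc1ccc(Cl)cc1Cl)C(=O)NCc1ccc(Cl)cc1` gives 39000 nM and compound 3 `Cc1cccc(CNC(=O)C(C)Oc2ccc(Cl)cc2Cl)c1` gives 45000 nM on the same read-out. Compound 3 thus stands level with the other two, within the usual scatter of both.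

Compound 4 `CC(Oc1ccc(Cl)cc1Cl)C(=O)NCc1ccc(F)cn1` has not been measured yet. It carries 5-fluoropyridin-2-yl in place of 3-methylphenyl on a saturated chain carbon bound to an amide-type nitrogen. Exchanging the ring at this place has so far changed little: the data show a 1.2-fold lower number from compound 1 to compound 2 (0.08 log units; within the scatter) and a 1.0-fold lower number from compound 1 to compound 3 (0.02 log units; within the scatter) and also a 1.2-fold higher number from compound 2 to compound 3 (0.06 log units; within the scatter) with none of them beyond the scatter. None of these three rings holds a hetero atom, so the measured steps cover the new ring only loosely. Even so, no step beyond the scatter is expected in this assay for this change. The expected move is a 1.1-fold higher number from compound 3 to compound 4 (0.05 log units; within the scatter) and no more. For compound 4 the estimate is 50000 nM with an expected range from 25000 nM to 95000 nM on this read-out.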

Compound 4, half-maximal inhibitory concentration: > 100000 nM
Compound 4 ended at the assay's limit (the forecaster's own chance of this, stated with the estimate: 20%); at least 2.0-fold (0.30 log units) between middle value and limit.
By their numbers in this assay, from the lowest: compounds 2, 3 and 1 (each within the scatter of the next). At a limit, above all of these: compound 4.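

Going by these compounds alone, until this result, swapping one all-carbon aromatic ring for another, on a saturated chain carbon bound to an amide-type nitrogen, had produced no step beyond the scatter in this assay. 5-Fluoropyridin-2-yl, the only ring here with a hetero atom (an atom other than carbon in the ring), gives steps beyond the scatter against all three earlier compounds: an at least 2.2-fold higher number from compound 3 to compound 4 (0.34 log units; beyond the scatter), an at least 2.5-fold higher number from compound 2 to compound 4 (0.40 log units; beyond the scatter) and an at least 2.1-fold higher number from compound 1 to compound 4 (0.32 log units; beyond the scatter). This position therefore does respond to the choice of ring, towards weaker inhibition, and the reading for compound 4 is a limit of the assay rather than a number: the limit of > 100000 nM in this assay, at which 1 of the 4 values shown sits.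

Going by these compounds, whether the ring nitrogen or the fluorine drives the step stays open, as compound 4 brings in both at once; a plain pyridin-2-yl ring and a 4-fluorophenyl ring would tell the two apart. Also open, on these data alone, are how far the true number for compound 4 lies from the others and how a ring carrying an amine or a carboxylic acid would read at this place.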